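Swapping trifluoromethyl for fluoro on an aromatic carbon

The source may report more compounds than this note shows. Statements on the series, on what has been measured and on what is new or still open speak of the compounds shown alone.

Values so far in a functional assay (aorta) for inhibition, with Rattus norvegicus as the target (a lower number here means a stronger inhibitor, a higher number a weaker inhibitor), for three compounds:
- compound 1 `C/N=C(\S)[C@]1(c2ccncc2)CCCC[S+]1[O-]` gives 25000 nM
- compound 2 `C/N=C(\S)[C@]1(c2cnc3ccccc3c2)CCCC[S+]1[O-]` gives 60 nM
- compound 3 `C/N=C(\S)[C@]1(c2cccc(C(F)(F)F)c2)CCCC[S+]1[O-]` gives 800 nM

Compound 3 sits in the middle of the three numbers. Compound 2 has a lower number and compound 1 a higher one, and both gaps lie beyond the usual scatter. The next compound, compound 4 `C/N=C(\S)[C@]1(c2cccc(F)c2)CCCC[S+]1[O-]`, has fluoro in place of trifluoromethyl on an aromatic carbon and is otherwise unchanged. Within the data shown here, no measured pair shows this swap, so there is no direct guide to the size of the step in this assay here. Among the measured compounds shown here, compound 1 at 25000 nM and compound 2 at 60 nM show only that numbers across this small set can lie far apart. A modest rise is expected, pointing to a somewhat weaker inhibitor, with wide uncertainty. The expected change is a 2.5-fold higher number from compound 3 to compound 4 (0.40 log units; beyond the scatter) in this direction. Compound 4 is estimated at 2000 nM with an expected range from 500 nM to 8000 nM in this test.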

Compound 4, concentration for 90% inhibition: 7000 nM
Compound 4: the middle estimate sits 3.5-fold (0.54 log units) below what was measured, within the range that was stated.
By their numbers in this assay, from the lowest: compound 2; then compound 3; then compound 4; then compound 1.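

In this assay, among these compounds, this is the first direct reading of a single change at this aromatic carbon: fluoro in place of trifluoromethyl gives an 8.8-fold higher number from compound 3 to compound 4 (0.94 log units; beyond the scatter), so the compound with fluoro is the weaker inhibitor. With the rest of the structure unchanged, the group at this position clearly matters, since this one swap moves the number beyond the usual scatter. Nothing available here explains the size or direction of this step.

The compounds shown leave open how a chloro group, a methoxy group or a nitrile at this position would compare with trifluoromethyl and fluoro. They also leave open whether the same swap would give a similar step with a different ring in place of this six-membered carbon ring.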